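Butyl to tert-Butyl on the Aromatic Ring of Compound 2

The source may hold more compounds than are shown below. What is called first, only, known or untested is meant among the compounds shown, and "the series" means these compounds.

Two measured compounds share one core and differ only in the alkyl group carried on the aromatic ring of the amide. In an in vitro functional assay on CHO/Galpha16 cells for antagonist activity at C-C chemokine receptor type 8 (Homo sapiens), read by FLIPR (on this read-out higher numbers stand for weaker inhibition and lower numbers for stronger inhibition), compound 1 `CCCC(=O)N1CCC(NS(=O)(=O)c2ccc(NC(=O)c3ccc(CC)cc3)c3ccccc23)CC1` gives 10.8 nM. Compound 2 `CCCCc1ccc(C(=O)Nc2ccc(S(=O)(=O)NC3CCN(C(=O)CCC)CC3)c3ccccc23)cc1` gives 15.3 nM in this assay, and this is the highest of the two numbers, the only other one being that of compound 1, a difference recorded as a 1.4-fold higher number from compound 1 to compound 2 (0.15 log units; within the scatter), so the two compounds cannot be told apart on these data.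

Compound 3 `CCCC(=O)N1CCC(NS(=O)(=O)c2ccc(NC(=O)c3ccc(C(C)(C)C)cc3)c3ccccc23)CC1` is the next step: tert-butyl in place of butyl on an aromatic carbon. For the measured compounds named here, no measured step addresses branching of this chain; the single step from compound 1 to compound 2, lengthening the chain, stayed within the scatter, and nothing in the data points to a shift in either direction. The expected step in this assay is therefore a 1.0-fold lower number from compound 2 to compound 3 (0.01 log units; within the scatter), that is, no change beyond the scatter. Compound 3 is accordingly estimated at 15 nM in this assay, with a range from 6 nM to 40 nM.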

Compound 3, half-maximal inhibitory concentration: 6.9 nM
The estimate for compound 3 lay 2.2-fold (0.34 log units) above the measured number; measured number inside the range.
By their numbers in this assay, from the lowest: compounds 3, 1 and 2 (each within the scatter of the next, the first and the last beyond it).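

In this assay, for the compounds shown here, the rearrangement of butyl to tert-butyl on an aromatic carbon para to a large group gives a 2.2-fold lower number from compound 2 to compound 3 (0.35 log units; beyond the scatter), the first step at this position to lie beyond the scatter, though only modestly. The two groups carry the same count of carbon atoms, so this position registers how those atoms are joined and not only how many there are, at least for this pair. Set against the ethyl group, the same position gives a 1.6-fold lower number from compound 1 to compound 3 (0.19 log units; within the scatter), so tert-butyl and ethyl cannot be told apart, and nothing available bears on what lies behind the separation between the tert-butyl and butyl compounds.

The compounds shown leave open how an isopropyl group, a cyclopropyl group or a longer branched chain would read at this position, and so whether the tert-butyl result reflects branching in general or this one group alone. They also leave open whether anything other than a simple alkyl group, such as a methoxy group, an amine or a carboxylic acid, would keep inhibition in this range.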